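A few compounds are considered here, and "the series" means these few. Any claim that something is new, unique, unknown or untested is made for them only; others in the source may bear on it.

Of the compounds shown here, three built on a shared core have so far been measured in a functional assay on MT4 cells (Homo sapiens) for antiproliferative activity, read by MTT assay, with a stated time of 96 h; on this read-out higher numbers stand for an effect only at larger amounts of compound and lower numbers for an effect already at smaller amounts. Compound 1 `CC(=O)/C(=C\c1c(-c2ccccc2)[nH]c2ccccc12)S(=O)(=O)c1ccccc1` gives 400 nM. Compound 2 `N#C/C(=C\c1c(-c2ccccc2)[nH]c2ccccc12)C(=O)Nc1ccc(Cl)cc1` gives 1700 nM, and compound 3 `CCOC(=O)/C(=C/c1c(-c2ccccc2)[nH]c2ccccc12)C(=O)c1ccc([N+](=O)[O-])cc1` gives 1500 nM. Among these three numbers compound 2 stands highest; its number and that of compound 3 lie within the usual scatter of each other, so no order between them can be claimed, whereas the gap down to the number of compound 1 lies beyond the scatter.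

Compound 4 `N#C/C(=C\c1c(-c2ccccc2)[nH]c2ccccc12)C(=O)c1ccc(Cl)cc1` has not yet been measured in this assay. It differs from compound 2 in one place: 4-chlorophenyl in place of (4-chlorophenyl)amino on a carbonyl carbon. Among the compounds with values here, no measured pair shows this exact change, so its effect has to be inferred. Compound 3, which likewise has a carbonyl carbon bound directly to an aromatic ring rather than through a nitrogen, gives a number close to that of compound 2, which suggests that this kind of link need not move the read-out far. The step from compound 2 to compound 4 in this assay is therefore expected to be small, a 1.4-fold lower number from compound 2 to compound 4 (0.15 log units; within the scatter), and it could fall on either side within the scatter. Compound 4 is thus estimated to give 1200 nM in this assay, with a range from 400 nM to 3600 nM.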

Compound 4, half-maximal effective concentration: 400 nM
Beside the measured number, compound 4's estimate is 3.0-fold (0.48 log units) above it; low and high end bracket the measured number.
By their numbers in this assay, from the lowest: compounds 1 and 4 (each within the scatter of the next); then compounds 3 and 2 (each within the scatter of the next).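

In this assay, within the data shown here, the change on the carbonyl carbon is the first single-place step that can be read, and 4-chlorophenyl in place of (4-chlorophenyl)amino gives a 4.3-fold lower number from compound 2 to compound 4 (0.63 log units; beyond the scatter) as a modest step beyond the scatter. Among these compounds, compound 2 and compound 4 are otherwise the same, so the step belongs to this one place, where the count shows the loss of the nitrogen and its hydrogen-bond donor; the earlier compounds differed from one another in more than one place and could not single this out. Nothing available explains why the number drops with this change.

The compounds shown leave open whether the step follows from removing the nitrogen as an atom or from removing its hydrogen, since a methylated nitrogen, a methylene or an oxygen on the carbonyl carbon would separate those two readings. They also leave open how much the aromatic ring and its chlorine contribute at this place, which a plain phenyl, a small alkyl chain or a carboxylic acid there would begin to show.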